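This account rests on a few compounds, and the source may have more. Where it says the series, first, only, none or still open, it means among the compounds named here.

Measured in an ADME assay on AGS cells (Homo sapiens) for cytotoxicity, read by neutral red uptake, with a stated time of 24 h; on this read-out lower numbers stand for stronger inhibition and higher numbers for weaker inhibition:
- compound 1 `CC(=O)Oc1c(C(C)C)cc2c3c1OC(=O)[C@@]31CCCC(C)(C)[C@@H]1CC2`: 275000 nM
- compound 2 `CCC(=O)Oc1c(C(C)C)cc2c3c1OC(=O)[C@@]31CCCC(C)(C)[C@@H]1CC2`: 113000 nM
- compound 3 `CC(C)c1cc2c3c(c1OC(=O)c1ccccc1)OC(=O)[C@@]31CCCC(C)(C)[C@@H]1CC2`: 503000 nM

Compound 3 stands at 503000 nM. One comparison does not separate it from its neighbour: a 1.8-fold higher number from compound 1 to compound 3 (0.26 log units; within the scatter). The other comparison does: a 4.5-fold higher number from compound 2 to compound 3 (0.65 log units; beyond the scatter).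

Compound 4 `CC(C)c1cc2c3c(c1OC(=O)Cc1c[nH]c4ccccc14)OC(=O)[C@@]31CCCC(C)(C)[C@@H]1CC2` carries (1H-indol-3-yl)methyl in place of phenyl on a carbonyl carbon. Within the data shown here, no measured compound carries this group, so the evidence is indirect. Two measured steps changed the group on this same carbonyl carbon, and they disagree in size. Phenyl in place of methyl stays within the scatter, while phenyl in place of ethyl is a modest change. A third step, a 2.4-fold lower number from compound 1 to compound 2 (0.39 log units; beyond the scatter), shows that lengthening the chain by methyl alone moved the number modestly.

Like compound 2, at 113000 nM, compound 4 has a saturated chain carbon on the carbonyl carbon, and that resemblance is the main reason for expecting a lower number. With so little to go on, only a modest fall in this assay is expected. The expected step is a 2.5-fold lower number from compound 3 to compound 4 (0.40 log units; beyond the scatter). Compound 4 is estimated at 200000 nM, with an expected range of 80000 nM to 500000 nM.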

Compound 4, half-maximal inhibitory concentration: 85600 nM
Compound 4: middle estimate off by 2.3-fold (0.37 log units), on the high side; the range from low to high includes it.
By their numbers in this assay, from the lowest: compounds 4 and 2 (each within the scatter of the next); then compounds 1 and 3 (each within the scatter of the next).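

In this assay, this carbonyl carbon tolerated a far bulkier group than any seen before: replacing phenyl with (1H-indol-3-yl)methyl gave a 5.9-fold lower number from compound 3 to compound 4 (0.77 log units; beyond the scatter), so an added two-ring unit carrying a hydrogen-bond donor did not raise the number. Placing 1H-indol-3-yl in place of hydrogen on the saturated chain carbon gave a 3.2-fold lower number from compound 1 to compound 4 (0.51 log units; beyond the scatter), whereas the same group in place of methyl there gave only a 1.3-fold lower number from compound 2 to compound 4 (0.12 log units; within the scatter), which leaves the large group and the small one indistinguishable at that carbon. Among these compounds, a substituent on the chain carbon, whether methyl or 1H-indol-3-yl, thus goes with a lower number than hydrogen does, but no measurement on hand accounts for the shifts.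

The compounds shown leave open whether benzyl, with a plain phenyl ring on the same saturated carbon, would behave like (1H-indol-3-yl)methyl, and whether the indole's ring nitrogen hydrogen matters at all, which an N-methylindole would test. They also leave open how an amine, a carboxylic acid or a longer chain such as butyl on this carbonyl carbon would fare.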